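A few compounds are considered here, and "the series" means these few. Any claim that something is new, unique, unknown or untested is made for them only; others in the source may bear on it.

Measured compounds and their results:

Compound 1, `CNCC(=O)Nc1cc(OC)ccc1C(=O)c1ccc(OC)c2c1OC(C)(C)C=C2`, gives 620 nM in a functional assay on A2780 cells (Homo sapiens) for antiproliferative activity, read by MTT assay, with a stated time of 48 h; a lower number here means a stronger inhibitor, a higher number a weaker inhibitor.
Compound 2, `CNCC(=O)Nc1cc(OC)ccc1C(=O)c1ccc(OC)c2c1C=CC(C)(C)O2`, gives 1590 nM in this assay.
Compound 3, `CCNCC(=O)Nc1cc(OC)ccc1C(=O)c1ccc(OC)c2c1OC(C)(C)C=C2`, gives 1980 nM in this assay.

Compounds 1 and 2 are built from the same atoms joined differently; the difference between the two cores is not broken down here. Compound 1 and compound 3 share one core, and so do compound 2 and compound 4, the not yet measured compound `CCNCC(=O)Nc1cc(OC)ccc1C(=O)c1ccc(OC)c2c1C=CC(C)(C)O2`.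

Within the first pair the change is methyl in place of hydrogen on a saturated chain carbon bound to an amine nitrogen, and this change made a step of a 3.2-fold higher number from compound 1 to compound 3 (0.50 log units; beyond the scatter), a weakening that goes beyond the scatter of the method. Within the second pair the change is methyl in place of hydrogen on a saturated chain carbon bound to an amine nitrogen, the same change at the same place, on a different core. Compound 2 and compound 3 give numbers within the scatter of each other, so nothing is read from their comparison.

Among the compounds with values here, from compound 2 to compound 4 the expected step is a 3.1-fold higher number from compound 2 to compound 4 (0.50 log units; beyond the scatter), estimated because the step of a 3.2-fold higher number from compound 1 to compound 3 (0.50 log units; beyond the scatter) shows what this change did once before, and there is no second example to say whether the other core would behave alike. Compound 4 is therefore expected to give about 5000 nM in this assay, with a plausible range from 2000 nM to 12000 nM.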

Compound 4, half-maximal inhibitory concentration: 4090 nM
Estimate against measurement, compound 4: 1.2-fold (0.09 log units) above; the range from low to high includes it.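

In this assay, putting ethylamino in place of methylamino on the core of compound 2 gave a 2.6-fold higher number from compound 2 to compound 4 (0.41 log units; beyond the scatter), so this core also lost potency with the change. The change therefore carried over between the two cores, with the same direction and with sizes that cannot be told apart: the same change on two cores in this assay, a 3.2-fold higher number (0.50 log units; beyond the scatter) from compound 1 to compound 3 and a 2.6-fold higher number (0.41 log units; beyond the scatter) from compound 2 to compound 4, 1.2-fold (0.09 log units) apart, within the scatter of two such steps. Within the data shown here, this agreement rests on only two matched pairs, so it supports treating the step as transferable between these two cores, but it does not show that the step would hold on any other core, and it does not explain why the ethyl group weakens the compounds.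

The compounds shown cover only methylamino and ethylamino at this end of the side chain, so it remains open whether a longer chain such as propyl, a branched group such as isopropyl, or a ring amine such as pyrrolidine would weaken the compounds further on either core. Also open, going by these compounds, is what a primary amine, with no carbon group on the nitrogen at all, would do, and whether the two cores would still respond alike to any of these groups.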